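Amide aryl swap on the shared core: compound 3

The compounds below may be only part of what the source reports. "The series", "measured", "known", "first", "only" and "open" are said of these compounds alone.

Within the data shown here, compound 2 `CCn1cc(C(=O)Nc2ccccc2N)c(=O)c2cc(F)c(N3CCNC(C)C3)c(F)c21` carries the only plain number in this set: in a functional assay on Bel-7402 cells (Homo sapiens) for cytotoxicity, read by MTT assay (a higher number here means a weaker inhibitor, a lower number a stronger inhibitor), compound 2 gives 4800 nM. Compound 1 `CCn1cc(C(=O)Nc2ccccc2O)c(=O)c2cc(F)c(N3CCNC(C)C3)c(F)c21` returns only a limit of the assay, > 50000 nM. Among the measured compounds shown here, that limit of > 50000 nM in this assay, at which 1 of the 2 values shown sits, is the sole evidence on the single measured step, an at least 10-fold lower number from compound 1 to compound 2 (1.01 log units; beyond the scatter). For the measured compounds named here, compound 3 `CCn1cc(C(=O)Nc2cccc([N+](=O)[O-])c2)c(=O)c2cc(F)c(N3CCNC(C)C3)c(F)c21` differs by 3-nitrophenyl in place of 2-aminophenyl on an amide-type nitrogen, removing the amino that distinguishes compound 2 from compound 1 and bringing in a nitro that no measured step covers. Going by the values given here, only the step from compound 1 to compound 2 bears on it, and only partly. Compound 3 is therefore expected to be weaker, a 4.2-fold higher number from compound 2 to compound 3 (0.62 log units; beyond the scatter), with an estimate of 20000 nM between 5000 nM and 80000 nM.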

Compound 3, half-maximal inhibitory concentration: 1000 nM
For compound 3 the middle estimate is 20-fold (1.30 log units) above the measured one; measured number below the stated range.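

The amino of compound 2 is not required for a low number in this assay on this aryl group: 3-nitrophenyl in place of 2-aminophenyl gives a 4.8-fold lower number from compound 2 to compound 3 (0.68 log units; beyond the scatter) on the shared core. Set against 2-hydroxyphenyl, the same aryl group gives an at least 50-fold lower number from compound 1 to compound 3 (1.69 log units; beyond the scatter) on that core. Compound 1 stands at a limit of the assay, so that step is only a bound: the limit of > 50000 nM in this assay, at which 1 of the 3 values shown sits.

The nitro and its place on the ring change together here, leaving 2-nitrophenyl and 3-aminophenyl as the open comparisons. Also open, from the compounds shown here alone, is how a nitrile or a carboxylic acid in place of the nitro would read.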